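Fluoro for Chloro on the Shared Core: Hepatocyte Clearance

The compounds below may be only part of what the source reports. "The series", "measured", "known", "first", "only" and "open" are said of these compounds alone.

Compound 2 `CC(C)n1nc(-c2ccc3oc(N)nc3c2)c2c(Cl)nc(N)nc21` is followed here in an ADME assay on cells (Hepatocyte, Homo sapiens) for metabolic stability, read by LC-MS, with a stated time of 90 min, tested at 1 uM (a higher number here means faster removal of the compound, a lower number slower removal), alongside compound 1 `CCc1nc(N)nc2c1c(-c1ccc3oc(N)nc3c1)nn2C(C)C`. In this assay compound 1 gives < 5 uL/min, which is a limit of the assay rather than a number. In this assay compound 2 gives 11 uL/min, the only number shown among the two compounds. Among the measured compounds shown here, the step of an at least 2.2-fold higher number from compound 1 to compound 2 (0.34 log units; beyond the scatter) is the single measured step, and it rests on (the limit of < 5 uL/min in this assay, at which 1 of the 2 values shown sits).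

Compound 3 `CC(C)n1nc(-c2ccc3oc(N)nc3c2)c2c(F)nc(N)nc21` differs from compound 2 by fluoro in place of chloro on an aromatic carbon. For the measured compounds named here, this exchange of one halogen for another on the same aromatic carbon has no measured counterpart: the one step, chloro in place of ethyl, is of a different kind and offers no direct guide. Compound 2 and its number therefore stand on their own as the anchor. A step no larger than the scatter is expected in this assay, in either direction, with a lower number no more likely than none.

Compound 3 is estimated at 8 uL/min, between 4 uL/min and 16 uL/min, which corresponds to the expected step of a 1.4-fold lower number from compound 2 to compound 3 (0.14 log units; within the scatter).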

Compound 3, intrinsic clearance in a liver preparation (reported as CLH), per the amount of preparation that the assay uses: 57 uL/min
Compound 3: middle estimate off by 7.1-fold (0.85 log units), on the low side, and the stated range ends below it.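

At this aromatic carbon, next to the ring nitrogen, the choice of halogen matters in this assay: fluoro in place of chloro gives a 5.2-fold higher number from compound 2 to compound 3 (0.71 log units; beyond the scatter). The earlier step, chloro in place of ethyl, had shown that this position responds, but it could not show how far, whereas this step has a number at both ends and shows that exchanging one halogen for the other can move clearance beyond the scatter. Among the three groups shown, the numbers rise from ethyl to chloro to fluoro, and the widest step, an at least 11-fold higher number from compound 1 to compound 3 (1.05 log units; beyond the scatter), gives only a lower bound on the gap between ethyl and fluoro: the limit of < 5 uL/min in this assay, at which 1 of the 3 values shown sits.

The compounds shown leave open where other groups at this carbon would fall in that order, such as an amine, a methoxy group, a nitrile or a longer alkyl chain. They also leave open why fluoro gives the higher number, and whether the same exchange would give a step of like size on any core other than the shared core.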